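The source may report more compounds than this note shows. Statements on the series, on what has been measured and on what is new or still open speak of the compounds shown alone.

Measured so far:
compound 1, `COc1ccc2c(/C=C/C(=O)c3cc(OC)c(OC)c([N+](=O)[O-])c3)c[nH]c2c1`: 742 nM
compound 2, `COc1cc(C(=O)/C=C/c2c[nH]c3ccccc23)cc([N+](=O)[O-])c1OC`: 1280 nM
compound 3, `COc1ccc2c(/C=C(\C)C(=O)c3cc(OC)c(OC)c([Se]C)c3)c[nH]c2c1`: 18 nM

In a functional assay on A2780 cells (Homo sapiens) for antiproliferative activity, read by MTT assay, with a stated time of 48 h (on this read-out lower numbers stand for stronger inhibition and higher numbers for weaker inhibition), compound 1 gives 742 nM and compound 2 gives 1280 nM. The step of a 1.7-fold higher number from compound 1 to compound 2 (0.24 log units; within the scatter) goes with the change (hydrogen in place of methoxy on an aromatic carbon). Compound 3 gives 18 nM in this assay, the lowest of the three numbers, its steps to compound 1 and compound 2 both lying beyond the scatter; how the core of compound 3 differs from the core of compound 1 is not broken down here.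

Compound 4, `COc1cc(C(=O)/C(C)=C/c2c[nH]c3ccccc23)cc([Se]C)c1OC`, is not yet measured. It differs from compound 3 by hydrogen in place of methoxy on an aromatic carbon, the same change, at the same place, as from compound 1 to compound 2. The step expected is a 1.7-fold higher number from compound 3 to compound 4 (0.22 log units; within the scatter), resting on the measured step of a 1.7-fold higher number from compound 1 to compound 2 (0.24 log units; within the scatter). Compound 4 is therefore estimated at 30 nM, with a range from 12 nM to 80 nM.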

Compound 4, half-maximal inhibitory concentration: 25 nM
Beside the measured number, compound 4's estimate is 1.2-fold (0.08 log units) above it; low and high end bracket the measured number.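

In this assay, hydrogen in place of methoxy on an aromatic carbon goes with a 1.4-fold higher number from compound 3 to compound 4 (0.14 log units; within the scatter), and this step agrees with the one on the other core: the same change on two cores in this assay, a 1.7-fold higher number (0.24 log units; within the scatter) from compound 1 to compound 2 and a 1.4-fold higher number (0.14 log units; within the scatter) from compound 3 to compound 4, 1.2-fold (0.09 log units) apart, within the scatter of two such steps
The change therefore carries from one core to the other without a step beyond the scatter, on both the core of compound 1 and the core of compound 3. For the compounds shown here, with only two pairs, each within the scatter, this does not show that the methoxy has a real effect on the numbers, nor that the agreement extends to cores outside these four compounds.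

The compounds shown leave open how other groups at this place, such as a hydroxyl, an amine or a longer alkoxy chain, would read. They also leave open which part of the difference between the core of compound 1 and the core of compound 3 goes with the gap in their numbers.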